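The source may hold more compounds than are shown below. What is called first, only, known or untested is meant among the compounds shown, and "the series" means these compounds.

Measured in a toxicity assay on MT2 cells (Homo sapiens) for cytotoxicity, read by XTT assay, with a stated time of 4 days; on this read-out higher numbers stand for lower toxicity in this test and lower numbers for higher toxicity in this test:

compound 1 `COc1cccc(CCOc2ccc(-c3c(C)nc(C)c([C@H](OC(C)(C)C)C(=O)O)c3N3CCC(C)(C)CC3)cc2)c1`: >= 33500 nM
compound 2 `Cc1nc(C)c([C@H](OC(C)(C)C)C(=O)O)c(N2CCC(C)(C)CC2)c1-c1ccc(OCCc2ccc(Cl)cc2)cc1`: >= 33500 nM
compound 3 `Cc1ccc(CCOc2ccc(-c3c(C)nc(C)c([C@H](OC(C)(C)C)C(=O)O)c3N3CCC(C)(C)CC3)cc2)s1`: >= 25000 nM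

Compound 3 stands only at a limit of this assay, and so do the two other values shown. The reading for compound 3 is the limit given by the limit of >= 25000 nM in this assay, at which 1 of the 3 values shown sits. The readings for compound 1 and compound 2 sit at the limit given by the limit of >= 33500 nM in this assay, at which 2 of the 3 values shown sit. Every value is a limit. Among the measured compounds shown here, none of the measured steps can be sized: a step that the two limits leave unreadable from compound 1 to compound 2, a step that the two limits leave unreadable from compound 1 to compound 3 and a step that the two limits leave unreadable from compound 2 to compound 3 are all unreadable. All three differ only in the aryl group on the saturated chain carbon, two bonds along the chain from an oxygen on an aromatic ring, and none of those exchanges brought a reading below a limit.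

Compound 4 `Cc1nc(C)c([C@H](OC(C)(C)C)C(=O)O)c(N2CCC(C)(C)CC2)c1-c1ccc(OCCc2cccnc2)cc1` differs from compound 3 as follows: pyridin-3-yl in place of 5-methylthiophen-2-yl on a saturated chain carbon, two bonds along the chain from an oxygen on an aromatic ring. The measured steps give no readable size, so no step beyond the scatter is expected for compound 4; its expected step is a step that the limit leaves unreadable from compound 3 to compound 4. Compound 4 is therefore estimated at 30000 nM, with a range from 12000 nM to 70000 nM, most likely again reported only as a limit.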

Compound 4, half-maximal cytotoxic concentration: >= 25000 nM
Compound 4: only a limit was reported; the forecaster's own chance of this, stated with the estimate: 75%; the middle value lies beyond the limit too.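

In this assay compound 4 gives >= 25000 nM, which is a limit. The steps linking compound 4 to compound 1, compound 2 and compound 3 cannot be read. The compounds shown leave open at what concentration any of the four becomes cytotoxic, and whether exchanging these aryl groups changes that concentration at all.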